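Removing a Methoxy Group: What to Expect for Compound 4

The source may hold more compounds than are shown below. What is called first, only, known or untested is meant among the compounds shown, and "the series" means these compounds.

Of the compounds shown here, three have been measured in an ADME assay on 184B5 cells (Homo sapiens) for antiproliferative activity, read by sulforhodamine B assay, with a stated time of 72 h; a higher number here means a weaker inhibitor, a lower number a stronger inhibitor. Compound 1 `Fc1ccc(/C=C\c2cc3ccccc3nc2Cl)cc1` gives 35700 nM. Compound 2 `COc1ccc2nc(Cl)c(/C=C\c3ccc(F)cc3)cc2c1` gives 19200 nM in this assay. Compound 3 `COc1ccc2nc(Cl)c(/C=C\c3cc(C(F)(F)F)cc(C(F)(F)F)c3)cc2c1` gives 7970 nM in this assay, the lowest of the three numbers, beyond the scatter from both others. The difference between the cores of compound 2 and compound 3 is not broken down here.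

Compound 1 and compound 2 differ in one place: hydrogen in place of methoxy on an aromatic carbon. This change made a step of a 1.9-fold higher number from compound 2 to compound 1 (0.27 log units; within the scatter). Compound 4 `FC(F)(F)c1cc(/C=C\c2cc3ccccc3nc2Cl)cc(C(F)(F)F)c1` has not yet been measured. It differs from compound 3 by the same change, at the same place: hydrogen in place of methoxy on an aromatic carbon.

A step of similar size is expected for compound 4, a 1.9-fold higher number from compound 3 to compound 4 (0.27 log units; within the scatter), because the earlier measured step was a 1.9-fold higher number from compound 2 to compound 1 (0.27 log units; within the scatter). Compound 4 is therefore estimated to give 15000 nM in this assay, expected to lie between 7000 nM and 32000 nM. This expectation rests on a single earlier instance of the change, so the range is kept wide.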

Compound 4, half-maximal inhibitory concentration: 13700 nM
Beside the measured number, compound 4's estimate is 1.1-fold (0.04 log units) above it, within the range that was stated.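

The new measurement in this assay gives a 1.7-fold higher number from compound 3 to compound 4 (0.24 log units; within the scatter), for hydrogen in place of methoxy on an aromatic carbon. Set beside the only earlier instance, the same change gives matching results on the two cores: the same change on two cores in this assay, a 1.9-fold higher number (0.27 log units; within the scatter) from compound 2 to compound 1 and a 1.7-fold higher number (0.24 log units; within the scatter) from compound 3 to compound 4, 1.1-fold (0.03 log units) apart, within the scatter of two such steps. Both steps lie within the scatter, however, so these pairs do not show that taking away the methoxy group truly moves the number, and two cores are too few to speak for the wider series.

The compounds shown leave open whether a different group at this same place, such as an amine, a carboxylic acid or a longer chain like butoxy, would give a step that rises beyond the scatter. They also leave open whether the match between the two steps would survive on a further core, for example one carrying an amine where compound 3 and compound 4 carry their trifluoromethyl groups.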